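Chloro to methoxy on a fused aromatic core

The source may report more compounds than this note shows. Statements on the series, on what has been measured and on what is new or still open speak of the compounds shown alone.

Compound 1 `[O-][n+]1nc(NCCN2CCCCC2)[n+]([O-])c2cc(Cl)ccc21`: 400 nM
Compound 2 `CCCN(CCC)CCNc1n[n+]([O-])c2ccc(Cl)cc2[n+]1[O-]`: 600 nM

In a functional assay on HT-29 cells (Homo sapiens) for cytotoxicity, with a stated time of 4 h (on this read-out lower numbers stand for stronger inhibition and higher numbers for weaker inhibition), compound 1 gives 400 nM, the lowest of the two numbers, and compound 2 gives 600 nM; the two sit within the scatter of each other. Among the compounds with values here, the only measured step, a 1.5-fold higher number from compound 1 to compound 2 (0.18 log units; within the scatter), changes the amine on the chain and not the aromatic ring, so nothing measured bears directly on compound 3 `COc1ccc2c(c1)[n+]([O-])c(NCCN1CCCCC1)n[n+]2[O-]`, which differs from compound 1 as methoxy in place of chloro on an aromatic carbon. Within the data shown here, with no step of this kind measured, no change beyond the scatter is expected; the step is estimated as a 1.5-fold higher number from compound 1 to compound 3 (0.18 log units; within the scatter). Compound 3 is expected to give about 600 nM, with a range from 200 nM to 1800 nM.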

Compound 3, half-maximal inhibitory concentration: 10800 nM
Estimate against measurement, compound 3: 18-fold (1.26 log units) below; measured number outside the range, above it.
By their numbers in this assay, from the lowest: compounds 1 and 2 (each within the scatter of the next); then compound 3.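

In this assay, methoxy in place of chloro on this aromatic carbon gives a 27-fold higher number from compound 1 to compound 3 (1.43 log units; beyond the scatter) and so moves the number far more than the change on the chain, which gives a 1.5-fold higher number from compound 1 to compound 2 (0.18 log units; within the scatter). On this evidence, the group on this aromatic carbon of the shared core matters more to the number than the amine swap does. No evidence here accounts for the size of this step.

On these data alone, it remains open whether the number follows the loss of chloro or the arrival of methoxy, which a fluoro, methyl or unsubstituted compound could help separate. As far as these compounds go, it is also open whether the same change would carry the same weight alongside the dipropylamino chain of compound 2.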